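This account rests on a few compounds, and the source may have more. Where it says the series, first, only, none or still open, it means among the compounds named here.

Compound 1 `O=C(/C=C/c1ccc(O)cc1)c1c(O)cccc1OCCC1CCCC1` and compound 2 `CC(C)(C)CCOc1cccc(O)c1C(=O)/C=C/c1ccc(C(=O)O)cc1` share a core and differ in their side chains. In a functional assay on NUGC-3 cells (Homo sapiens) for antiproliferative activity, read by sulforhodamine B assay (a higher number here means a weaker inhibitor of growth, a lower number a stronger inhibitor of growth), compound 1 gives 3200 nM. In this assay compound 2 gives 5440 nM. The gap between these two numbers lies within the scatter of repeated measurements, so compound 1 and compound 2 cannot be told apart on the evidence at hand, and no direction of change between them can be read.

Compound 3 `CC(C)CCCOc1cccc(O)c1C(=O)/C=C/c1ccc(O)cc1` is the next compound, not yet measured. It differs from compound 1 in one place: isobutyl in place of cyclopentyl on a saturated chain carbon, two bonds along the chain from an oxygen on an aromatic ring. One saturated hydrocarbon group is exchanged for another of nearly the same size, and nothing else moves. On that basis the step from compound 1 to compound 3 is expected to be small, a 1.1-fold higher number from compound 1 to compound 3 (0.05 log units; within the scatter), not beyond the scatter in either direction. Compound 3 is therefore estimated at 3600 nM, with a range from 1500 nM to 8500 nM.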

Compound 3, concentration for 50% growth inhibition: 3520 nM
Compound 3: the middle estimate sits 1.0-fold (0.01 log units) above what was measured, within the range that was stated.
By their numbers in this assay, from the lowest: compounds 1, 3 and 2 (each within the scatter of the next).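

Replacing the ring with an open, branched chain produces no readable change at this position: in this assay, isobutyl in place of cyclopentyl gives a 1.1-fold higher number from compound 1 to compound 3 (0.04 log units; within the scatter). Compound 1 and compound 3 therefore cannot be told apart, so the cyclopentyl ring is not needed to keep growth inhibition at this level, at least when the alternative is isobutyl. Nothing measured here explains why these two side chains read alike.

From the compounds shown here alone, both groups tried in this one-place comparison are saturated hydrocarbons of nearly the same size, so it remains open whether an amine or a much longer chain at this same place would shift the number. Going by these compounds, it is also open whether a group as small as methyl would keep it.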